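A few compounds are considered here, and "the series" means these few. Any claim that something is new, unique, unknown or untested is made for them only; others in the source may bear on it.

Compound 1 `FC(F)(F)c1cccc(-c2nc3cnc(Nc4ncccn4)cc3[nH]2)c1` gives < 5000 nM
Compound 2 `Fc1ccc(Nc2cc3[nH]c(-c4cccc(C(F)(F)F)c4)nc3cn2)nc1` gives < 5000 nM

Both entries come from a physicochemical assay for solubility, using the shake flask method, in phosphate buffer, measured as kinetic solubility, with a stated time of 20 h, at pH 6.5 (on this read-out higher numbers stand for higher solubility and lower numbers for lower solubility), and both are limits, not numbers. Compound 2 stands only at its limit of < 5000 nM, and so does compound 1, as the limit of < 5000 nM in this assay, at which 2 of the 2 values shown sit, records. Going by the values given here, the one measured step is a step that the two limits leave unreadable from compound 1 to compound 2, so it supplies no size to carry forward. Compound 3 `Fc1ccc(Nc2cc3[nH]c(-c4ccc(F)c(C(F)(F)F)c4)nc3cn2)nc1` has fluoro in place of hydrogen on an aromatic carbon, ortho to a trifluoromethyl group and para to a large group (fluoro in place of hydrogen on an aromatic carbon). Among the compounds with values here, no measured step covers this change, so no shift beyond the scatter is expected in either direction. The expected step is a step that the limit leaves unreadable from compound 2 to compound 3. For compound 3 the estimate is 2500 nM, with an expected range from 600 nM to 5000 nM.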

Compound 3, solubility: < 5000 nM
Compound 3: no number, only a limit; the forecaster's own chance of this, stated with the estimate: 90%; the middle value lies beyond the limit too.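

Compound 2 and compound 3 both stand only as limits, so no step can be read between them: the limit of < 5000 nM in this assay, at which 3 of the 3 values shown sit.

The compounds shown leave open where any of them truly lies in this assay, and whether fluoro in place of hydrogen shifts that read-out at all.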